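From tert-butyl to propyl on the saturated chain carbon

The source may hold more compounds than are shown below. What is called first, only, known or untested is meant among the compounds shown, and "the series" means these compounds.

For the measured compounds named here, the three measured members, compound 1 `O=C(O)c1ccccc1-c1ccc(CCc2ncc(Cc3ccccc3F)[nH]2)cc1`, compound 2 `O=C(O)c1ccccc1-c1ccc(CCc2ncc(CCc3ccccc3)[nH]2)cc1` and compound 3 `CC(C)(C)Cc1cnc(CCc2ccc(-c3ccccc3C(=O)O)cc2)[nH]1`, share one core and differ only in the group on a saturated chain carbon bound to an aromatic carbon. In an in vitro functional assay on cells for agonist activity at Bombesin receptor subtype-3 (Homo sapiens), read by luminescence and calcium flux (a lower number here means that less compound is needed, a higher number that more compound is needed for the effect), compound 1 gives 177 nM, compound 2 gives 1320 nM and compound 3 gives 106 nM. Compound 3 carries the lowest number of the three, but one of its two gaps is within the scatter (a 1.7-fold lower number from compound 1 to compound 3 (0.22 log units; within the scatter)), while the other is clear (a 12-fold lower number from compound 2 to compound 3 (1.10 log units; beyond the scatter)). Compound 4 `CCCCc1cnc(CCc2ccc(-c3ccccc3C(=O)O)cc2)[nH]1` brings the change (propyl in place of tert-butyl on a saturated chain carbon bound to an aromatic carbon). Both measured steps end at the tert-butyl and exchange an aromatic group for it; neither exchanges one alkyl group for another, so the bearing is indirect. They show the tert-butyl holding level with the 2-fluorophenyl and well ahead of the benzyl, and give no reason to expect a large shift for a shorter alkyl chain. A modest rise in the number is expected, a 2.4-fold higher number from compound 3 to compound 4 (0.37 log units; beyond the scatter). Compound 4 is expected to give 250 nM in this assay, within 80 nM to 800 nM.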

Compound 4, half-maximal effective concentration: 2710 nM
Estimate against measurement, compound 4: 11-fold (1.04 log units) below; measured number outside the range, above it.
By their numbers in this assay, from the lowest: compounds 3 and 1 (each within the scatter of the next); then compound 2; then compound 4.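

In this assay, for the compounds shown here, the group on a saturated chain carbon bound to an aromatic carbon proves sensitive to an exchange of one alkyl group for another: propyl in place of tert-butyl gives a 26-fold higher number from compound 3 to compound 4 (1.41 log units; beyond the scatter) and is the largest step so far. Propyl in place of 2-fluorophenyl gives a 15-fold higher number from compound 1 to compound 4 (1.18 log units; beyond the scatter) and ethyl in place of phenyl, two bonds along the chain from an aromatic carbon, gives a 2.1-fold higher number from compound 2 to compound 4 (0.31 log units; beyond the scatter) so that compound 4 stands apart from all three earlier compounds, with the highest number. No measured evidence on the origin of this sensitivity is at hand.

One straight chain against one branched group does not separate chain length from branching; isopropyl, cyclopropyl or a longer chain such as pentyl would. On these data alone, how an amine at the end of the chain would read also remains open.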